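The source may hold more compounds than are shown below. What is called first, only, known or untested is meant among the compounds shown, and "the series" means these compounds.

Measured so far in an ADME assay on HEK-293T cells (Homo sapiens) for cytotoxicity, read by MTT assay, tested at 25 uM; on this read-out lower numbers stand for a stronger effect and higher numbers for a weaker effect at the one concentration tested:
compound 1 `CC(C)c1cc(C(=O)Nc2ncc([N+](=O)[O-])s2)c(O)c(C(C)C)c1` gives 29.4%
compound 2 `CC(=O)Oc1c(C(=O)Nc2ncc([N+](=O)[O-])s2)cc(C(C)C)cc1C(C)C` gives 45.9%
compound 3 `O=C(Nc1ncc([N+](=O)[O-])s1)c1ccc([N+](=O)[O-])o1` gives 87.4%

Compound 3 stands at the top of these three numbers, which on this read-out means the weakest effect on the cells; its nearest neighbour is compound 2, and compound 1 sits furthest below it. The step to compound 4 `Cc1ccc(-c2ccc(C(=O)Nc3ncc([N+](=O)[O-])s3)o2)cc1` changes the five-membered ring of compound 3: 4-methylphenyl in place of nitro on an aromatic carbon.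

For the measured compounds named here, the one step measured between two compounds that differ in a single place, a number 16.5 percentage points higher from compound 1 to compound 2 (beyond the scatter), concerns an acetyl in place of hydrogen on an oxygen and sits on the core of compound 1, not on the five-membered ring of compound 3. Going by the values given here, no measured step speaks to swapping a nitro for a 4-methylphenyl on that ring. The expectation therefore rests only on the value of compound 3 and is loosely held. Compound 4 is expected to give a number near that of compound 3, with a number 12.4 percentage points lower from compound 3 to compound 4 (beyond the scatter) as the estimated shift, in a range wide enough to allow a drop beyond the scatter. The estimate for compound 4 is 75%, between 45% and 100%.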

Compound 4, a percentage reported as activity, at one concentration (the size of the read-out at that concentration, not a potency): 94.1%
Beside the measured number, compound 4's estimate is 19.1 percentage points below it; the measured number falls inside the stated range.
By their numbers in this assay, from the lowest: compound 1; then compound 2; then compounds 3 and 4 (each within the scatter of the next).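

In this assay, the swap of nitro for 4-methylphenyl on an aromatic carbon of the five-membered aromatic ring with 1 oxygen, next to the ring oxygen, gives a number 6.7 percentage points higher from compound 3 to compound 4 (within the scatter), so the two compounds cannot be told apart on this read-out. For the compounds shown here, this is the first measured change at this position, and it shows that a nitro group is not required there for the reading of compound 3 to hold: a larger group built of carbon only, carrying a six-membered aromatic ring, gives a number within the scatter of it. Nothing available explains why so different a group leaves the two readings indistinguishable.

On these data alone, this is a single swap, so it remains open whether a small group such as an amine, or a charged one such as a carboxylic acid, on the same carbon would also stay within the scatter of compound 3. As far as these compounds go, it is equally open whether the methyl on the new ring plays any part, which a plain phenyl or a longer chain in its place could test.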